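A few compounds are considered here, and "the series" means these few. Any claim that something is new, unique, unknown or untested is made for them only; others in the source may bear on it.

Measured compounds in a functional assay on the whole organism (artery, strain albino) with Rattus norvegicus as the target, with a stated time of 180 min, at a dose of 10 mg/kg by the oral route; a lower number here means less inhibition, a higher number more inhibition at the dose given (going by the name of the read-out):
compound 1, `COc1ccc(C2N=C(SCc3ccccc3)NC(C)=C2C(=O)Nc2ccc(F)cc2)cc1OC`, gives 12.9%
compound 2, `COc1ccc(C2N=C(SCc3ccccc3Cl)NC(C)=C2C(=O)Nc2ccc(F)cc2)cc1OC`, gives 25.3%
compound 3, `CC1=C(C(=O)Nc2ccc(F)cc2)C(c2ccc([N+](=O)[O-])cc2)N=C(SCc2ccccc2)N1`, gives 23.7%

Compound 3 stands second highest of the three numbers. Its nearest neighbour is compound 2, whose value lies within the scatter of that of compound 3, so no order between these two can be read. Compound 1 lies beyond the scatter below compound 3, and the step from it to compound 3 is a number 10.8 percentage points higher from compound 1 to compound 3 (beyond the scatter).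

The unmeasured compound 4, `CC1=C(C(=O)Nc2ccc(F)cc2)C(c2ccc([N+](=O)[O-])cc2)N=C(SCc2cccc(Cl)c2)N1`, differs from compound 3 by chloro in place of hydrogen on an aromatic carbon. Among the compounds with values here, one measured step bears on this change: the same exchange, a chloro in place of hydrogen on an aromatic carbon of the benzylsulfanyl ring, gave a number 12.4 percentage points higher from compound 1 to compound 2 (beyond the scatter). That step is modest but beyond the scatter, so a modest rise is expected in this assay for compound 4 as well, though the chloro enters at a different place on the ring, which adds uncertainty. Compound 4 is therefore expected to show a step of a number 9.3 percentage points higher from compound 3 to compound 4 (within the scatter), giving an estimate of 33% with a range from 20% to 46%.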

Compound 4, a percentage reported as inhibition, in the whole organism at one dose (the size of the read-out at that dose, not a potency): 11.9%
For compound 4 the middle estimate is 21.1 percentage points above the measured one; the measured number lies below the stated range.
By their numbers in this assay, from the lowest: compounds 4 and 1 (each within the scatter of the next); then compounds 3 and 2 (each within the scatter of the next).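

In this assay, chloro in place of hydrogen on the aromatic ring of the benzylsulfanyl group has no single direction: the change to (3-chlorobenzyl)sulfanyl gives a number 11.8 percentage points lower from compound 3 to compound 4 (beyond the scatter) and takes the number down rather than up. The earlier compounds shown here showed only a rise for this exchange, whereas the two steps now point in opposite directions: the same change on two cores in this assay, a number 12.4 percentage points higher (beyond the scatter) from compound 1 to compound 2 and a number 11.8 percentage points lower (beyond the scatter) from compound 3 to compound 4, 24.2 percentage points apart, beyond the scatter of two such steps. The two steps differ both in the group on the saturated ring carbon and in where the chloro sits on the ring, so these compounds cannot tell which of the two decides the direction.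

On these data alone, it remains open what the 3-chlorobenzyl group would do on the core of compound 1, which carries 3,4-dimethoxyphenyl. As far as these compounds go, whether a methoxy group or an amine at the place of this chloro would follow either step also stays open.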